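Furan-bearing series: trifluoromethyl replaced by ethyl

The compounds below may be only part of what the source reports. "The series", "measured", "known", "first", "only" and "open" are said of these compounds alone.

Measured so far in an assay on CHO cells for displacement of a labelled ligand from adenosine receptor A1 (Homo sapiens), with a stated time of 60 min, tested at 10 uM; a lower number here means less inhibition, a higher number more inhibition at the concentration tested (going by the name of the read-out):
compound 1, `CC1=C(C(N)=O)C(c2ccco2)NC(=O)N1`, gives 2%
compound 2, `CC1=C(C(=O)OC(C)(C)C)C(c2ccco2)NC(=O)N1`, gives 4%
compound 3, `CCOC(=O)C1=C(C(F)(F)F)NC(=O)NC1c1ccco1`, gives 15%

Compound 3 holds the highest of the three numbers in this assay. The nearest to it is compound 2, and the two values show compound 3 above compound 2 by more than the usual scatter; the gap to compound 1 is wider still. For the measured compounds named here, the only step measured within one change is a number 2 percentage points higher from compound 1 to compound 2 (within the scatter), which tells nothing about the ring carbon that carries the trifluoromethyl group.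

The next compound, compound 4, `CCOC(=O)C1=C(CC)NC(=O)NC1c1ccco1`, differs from compound 3 in one place: ethyl in place of trifluoromethyl on a double-bonded ring carbon. Going by the values given here, no measured pair in this set involves a change at that ring carbon, and no pair involves a trifluoromethyl or an ethyl group, so nothing here speaks to the direction or size of the step. Among the compounds with values here, the one step on record, from compound 1 to compound 2, stayed within the scatter. With no evidence either way, the expectation for compound 4 in this assay is a step of a number 3 percentage points lower from compound 3 to compound 4 (within the scatter), that is, none beyond the scatter. Compound 4 is therefore estimated at 12%, with a range from 0% to 28%.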

Compound 4, a percentage reported as inhibition, at one concentration (the size of the read-out at that concentration, not a potency): 29%
Compound 4: middle estimate off by 17 percentage points, on the low side, outside the stated range (above it).
By their numbers in this assay, from the lowest: compounds 1 and 2 (each within the scatter of the next); then compound 3; then compound 4.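

For the compounds shown here, the double-bonded ring carbon next to the ring nitrogen is the first position where a single change shifts the read-out beyond the scatter: this assay records a number 14 percentage points higher from compound 3 to compound 4 (beyond the scatter) on exchange of trifluoromethyl for ethyl, whereas the only earlier step, a number 2 percentage points higher from compound 1 to compound 2 (within the scatter) on the carbonyl carbon, stayed within it. The counted differences between the two groups are limited to heavy atoms and their elements, trifluoromethyl having 4 heavy atoms (1 carbon, 3 fluorine) and ethyl having 2 (both carbon), with neither group carrying a hydrogen-bond donor, a hydrogen-bond acceptor or a net charge. The number is therefore higher with ethyl than with trifluoromethyl at this position in this furan-2-yl compound with an ethoxycarbonyl group, but nothing available assigns the step to any particular feature of either group.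

Going by these compounds alone, this rests on one pair, so it remains open whether the same exchange gives a similar step with the tert-butoxycarbonyl or amide groups seen in the earlier compounds. Also open, from the compounds shown here alone, is how the number would respond at this ring carbon to a longer chain such as butyl, to a cyclopropyl ring, or to an aminomethyl group.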